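Swapping a sulfoximine for a trifluoromethyl carbinol on the shared core

The source may report more compounds than this note shows. Statements on the series, on what has been measured and on what is new or still open speak of the compounds shown alone.

Compound 1 `CC#C[C@H]1CN(S(=O)(=O)c2ccc(N)nc2)CCN1c1ccc(S(=O)(=NC)C(F)(F)F)cc1` was tested in an assay on cells (Hepatocyte) for inhibition of glucokinase regulatory protein (Mus musculus), with stated times of 20 min and 40 min (on this read-out lower numbers stand for an effect already at smaller amounts and higher numbers for an effect only at larger amounts of compound), where compound 1 gives 2060 nM. Among the two measured compounds this is the highest number, yet the only neighbour is close: compound 2 `CC#C[C@H]1CN(S(=O)(=O)c2ccc(N)nc2)CCN1c1ccc(C(C)(O)C(F)(F)F)nc1` gives 1450 nM in this assay, and the gap between the two lies within the usual scatter, so no order between them can be read off.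

Compound 3 `CC#CCC(O)(c1ccc(N2CCN(S(=O)(=O)c3ccc(N)nc3)C[C@@H]2C#CC)cc1)C(F)(F)F` has not been measured. It differs from compound 1 in one place: a group of 10 heavy atoms (6 carbon, 1 oxygen, 3 fluorine; no ring) in place of a group of 8 heavy atoms (2 carbon, 1 nitrogen, 1 oxygen, 3 fluorine, 1 sulfur; no ring), on an aromatic carbon. The group that leaves carries a sulfur atom with a nitrogen and an oxygen attached; the group that enters is a tertiary alcohol bearing a trifluoromethyl and a short chain with one triple bond.

Within the data shown here, no measured pair shows this change directly, so the expected step rests only on the two values shown. Compound 2 already carries a trifluoromethyl carbinol of a simpler kind and sits within the scatter of compound 1. For compound 3 a step toward lower numbers of a 5.2-fold lower number from compound 1 to compound 3 (0.71 log units; beyond the scatter) is expected, though with wide uncertainty. The estimate for compound 3 is 400 nM, with a range from 100 nM to 1600 nM.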

Compound 3, half-maximal effective concentration: 137 nM
Compound 3: the middle estimate sits 2.9-fold (0.47 log units) above what was measured; measured number inside the range.
By their numbers in this assay, from the lowest: compound 3; then compounds 2 and 1 (each within the scatter of the next).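

In this assay, the aromatic carbon para to a large group turns out to be a place where the choice of substituent matters: exchanging the sulfur-bearing group for the tertiary alcohol bearing a trifluoromethyl and a short chain with one triple bond goes with a 15-fold lower number from compound 1 to compound 3 (1.18 log units; beyond the scatter). The two earlier compounds lay within the scatter of each other, so they had shown no clear difference in this assay, whereas this single change on the shared core moves the number well beyond the scatter. Nothing measured here says which feature of the entering group accounts for this step.

The change replaces several features at once, including the sulfur atom with its attached nitrogen and oxygen, and it adds both a hydrogen-bond donor and a triple bond, so the contribution of each part remains unresolved. On these data alone, it remains open whether a saturated butyl chain in place of the chain with the triple bond would give a similar number, and whether an amine or a methyl ether could stand in for the hydroxyl.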